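Swapping 3-chlorophenyl for 4-cyanophenyl: a small expected step

The source may hold more compounds than are shown below. What is called first, only, known or untested is meant among the compounds shown, and "the series" means these compounds.

In a functional assay on MDA-MB-231 cells (Homo sapiens) for inhibition, read by MTT assay, with a stated time of 5 days (on this read-out higher numbers stand for weaker inhibition and lower numbers for stronger inhibition), compound 1 `Cc1cc(Nc2nc(NCc3cccc(Cl)c3)nc3[nH]ncc23)n[nH]1` gives 6860 nM, the second highest of three numbers. Compound 2 `Cc1cc(Nc2nc(NCc3ccc(Cl)cc3)nc3[nH]ncc23)n[nH]1` gives 7500 nM, and compound 3 `Cc1cc(Nc2nc(NCc3ccc(F)cc3F)nc3[nH]ncc23)n[nH]1` gives 2670 nM. Compound 4 `Cc1cc(Nc2nc(NCc3ccc(C#N)cc3)nc3[nH]ncc23)n[nH]1` is still unmeasured: it has 4-cyanophenyl in place of 3-chlorophenyl on a saturated chain carbon bound to a nitrogen on an aromatic ring. Exchanging 3-chlorophenyl for 4-chlorophenyl gave a 1.1-fold higher number from compound 1 to compound 2 (0.04 log units; within the scatter). The 2,4-difluorophenyl group gave modest steps, a 2.6-fold lower number from compound 1 to compound 3 (0.41 log units; beyond the scatter) and a 2.8-fold lower number from compound 2 to compound 3 (0.45 log units; beyond the scatter). No nitrile has been measured in this set, so these steps are only a rough guide. The expected step is a 1.1-fold lower number from compound 1 to compound 4 (0.06 log units; within the scatter), nothing beyond the scatter. Compound 4 is estimated at 6000 nM, with an expected range of 2500 nM to 14000 nM.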

Compound 4, half-maximal inhibitory concentration: 1360 nM
Beside the measured number, compound 4's estimate is 4.4-fold (0.64 log units) above it; the whole stated range lies above it.
By their numbers in this assay, from the lowest: compounds 4 and 3 (each within the scatter of the next); then compounds 1 and 2 (each within the scatter of the next).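

At this position, on a saturated chain carbon bound to a nitrogen on an aromatic ring, the group on the phenyl ring can shift the number more than the two chlorophenyl compounds showed: cyano in place of chloro gave a clear step in this assay (a 5.5-fold lower number from compound 2 to compound 4 (0.74 log units; beyond the scatter)), and 4-cyanophenyl in place of 3-chlorophenyl gave a similar one (a 5.0-fold lower number from compound 1 to compound 4 (0.70 log units; beyond the scatter)). The 4-cyanophenyl and 2,4-difluorophenyl groups cannot be told apart here (a 2.0-fold lower number from compound 3 to compound 4 (0.29 log units; within the scatter)). No measurement available here explains these steps. From the compounds shown here alone, whether 3-cyanophenyl, or a phenyl ring carrying an amine or a carboxylic acid, would give a similar number remains open.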